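The source may hold more compounds than are shown below. What is called first, only, known or untested is meant among the compounds shown, and "the series" means these compounds.

Measured so far in an assay on isolated protein for inhibition of coagulation factor X (Oryctolagus cuniculus), tested at 1 uM; a lower number here means less inhibition, a higher number more inhibition at the concentration tested (going by the name of the read-out):
compound 1 `CC(C)(C)c1ccc(S(=O)(=O)N[C@H]2CCN(CCNc3ccncc3)C2=O)cc1` gives 14%
compound 2 `O=C1[C@@H](NS(=O)(=O)c2cc3cccnc3s2)CCN1Cc1cc2c[nH]ccc-2n1` gives 18%
compound 3 `CC(C)(C)c1ccc(S(=O)(=O)N[C@H]2CCN(Cc3cc4c[nH]ccc-4n3)C2=O)cc1` gives 14%

All three share one core; compound 2 and compound 3 differ on the sulfonyl sulfur by a group of 9 heavy atoms (7 carbon, 1 nitrogen, 1 sulfur; one five-membered aromatic ring with 1 hetero atom, one six-membered aromatic ring with 1 hetero atom) in place of a group of 10 heavy atoms (10 carbon; one six-membered aromatic ring of carbon only), on a sulfonyl sulfur, and the step of a number 4 percentage points lower from compound 2 to compound 3 (within the scatter) shows this exchange left the read-out where it was. On the other side of the core, compound 1 arises from compound 3 through (a group of 8 heavy atoms (6 carbon, 2 nitrogen; one six-membered aromatic ring with 1 hetero atom) in place of a group of 9 heavy atoms (7 carbon, 2 nitrogen; one five-membered aromatic ring with 1 hetero atom, one six-membered aromatic ring with 1 hetero atom), on a saturated chain carbon bound to an amide-type nitrogen in a ring), and this gave no change at the digits printed from compound 3 to compound 1 (within the scatter), again no movement beyond the scatter.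

Compound 4 `O=C1[C@@H](NS(=O)(=O)c2cc3cccnc3s2)CCN1CCNc1ccncc1` has not yet been measured in this assay. It stands to compound 2 as compound 1 stands to compound 3: the change is a group of 8 heavy atoms (6 carbon, 2 nitrogen; one six-membered aromatic ring with 1 hetero atom) in place of a group of 9 heavy atoms (7 carbon, 2 nitrogen; one five-membered aromatic ring with 1 hetero atom, one six-membered aromatic ring with 1 hetero atom), on a saturated chain carbon bound to an amide-type nitrogen in a ring, and the place is worded the same in both cases, so it is the same change. Among the measured compounds shown here, because the only measured instance gave no change at the digits printed from compound 3 to compound 1 (within the scatter), the step is expected to be about a number 1 percentage points lower from compound 2 to compound 4 (within the scatter). For the measured compounds named here, compound 4 is therefore estimated at 17%, with a likely range from 8% to 27%, given that nothing so far has moved the read-out beyond its scatter.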

Compound 4, a percentage reported as inhibition, at one concentration (the size of the read-out at that concentration, not a potency): 23%
The estimate for compound 4 lay 6 percentage points below the measured number; measured number inside the range.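

Working notes on the series: in this assay, putting ((pyridin-4-yl)amino)methyl in place of the group with the five- and six-membered aromatic rings, on a saturated chain carbon bound to an amide-type nitrogen in a ring, gave a number 5 percentage points higher from compound 2 to compound 4 (within the scatter). Set beside the earlier step, the exchange reads the same on both cores: the same change on two cores in this assay, no change at the digits printed (within the scatter) from compound 3 to compound 1 and a number 5 percentage points higher (within the scatter) from compound 2 to compound 4, 5 percentage points apart, within the scatter of two such steps. This shows only that the exchange stayed within the scatter on the two cores shown; since neither step is a measurable effect, it does not show that an effect of this change carries from one core to another, nor that the two sulfonyl groups make no difference at higher read-outs.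

Still open, as far as these compounds go, is whether any group at this place moves the read-out beyond the scatter, for example a primary amine, a carboxylic acid or a longer chain ending in the same pyridine ring. Also open, from the compounds shown here alone, is whether a chlorophenyl group on the sulfonyl sulfur would do so.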